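This account rests on a few compounds, and the source may have more. Where it says the series, first, only, none or still open, it means among the compounds named here.

Measured so far:
compound 1 `CC/N=c1/c(C#N)c2n(c(=O)n1-c1ccccc1)CCC2`, 23.2%
compound 2 `C=CC/N=c1/c(C#N)c2n(c(=O)n1-c1ccccc1)CCC2`, 19%

Both compounds were tested in a functional assay on the whole organism (strain albino) for inhibition, with Rattus norvegicus as the target, read by paw edema, with a stated time of 2 h, at a dose of 0.029 mmol/kg by the oral route; on this read-out lower numbers stand for less inhibition and higher numbers for more inhibition at the one dose given (going by the name of the read-out). On that read-out compound 1 gives 23.2% and compound 2 gives 19%; the step of a number 4.2 percentage points lower from compound 1 to compound 2 (within the scatter) lies within the scatter, so compound 2 and compound 1 cannot be told apart on the numbers shown. Compound 3 `CCCC/N=c1/c(C#N)c2n(c(=O)n1-c1ccccc1)CCC2` is the next step from compound 2: propyl in place of vinyl on a saturated chain carbon bound to a double-bonded nitrogen. Among the measured compounds shown here, the only measured step that bears on it is the one from compound 1 to compound 2, a vinyl in place of methyl at the same place, which stayed within the scatter. Nothing in the two measured compounds therefore points to a change beyond the scatter in this assay, and the expected step is a number 2 percentage points higher from compound 2 to compound 3 (within the scatter). For compound 3 the estimated value is 21%, expected to fall between 8% and 34%.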

Compound 3, a percentage reported as inhibition, in the whole organism at one dose (the size of the read-out at that dose, not a potency): 24%
Compound 3: middle estimate off by 3 percentage points, on the low side; the range from low to high includes it.
By their numbers in this assay, from the lowest: compounds 2, 1 and 3 (each within the scatter of the next).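

Propyl in place of vinyl on a saturated chain carbon bound to a double-bonded nitrogen stays within the scatter in this assay (a number 5 percentage points higher from compound 2 to compound 3 (within the scatter)), and so does ethyl in place of hydrogen on a saturated chain carbon, two bonds along the chain from a double-bonded nitrogen (a number 0.8 percentage points higher from compound 1 to compound 3 (within the scatter)). Among these three compounds, then, neither a longer chain nor the loss of the double bond gives a step beyond the scatter, so the read-out does not separate them. No outside measurement bears on this result.

As far as these compounds go, whether a group other than a plain carbon chain would move the number stays open, for example a chain ending in an amine or a carboxylic acid, or a benzyl group. From the compounds shown here alone, a much longer chain, such as octyl, is equally open.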